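Swapping Phenethyl for Furanyl on a Thiourea Amide

The compounds below may be only part of what the source reports. "The series", "measured", "known", "first", "only" and "open" are said of these compounds alone.

Compound 3 `O=C(CCc1ccccc1)NC(=S)N1CCc2c(OCCCCCOc3ccc(Cl)cc3)cccc21` was tested in an ADME assay on Huh-7 cells (Homo sapiens) for cytotoxicity; on this read-out lower numbers stand for higher toxicity in this test and higher numbers for lower toxicity in this test. In this assay compound 3 reaches only the limit of > 50000 nM. Compound 1 `NC(=S)N1CCc2c(OCCCCCOc3ccc(Cl)cc3)cccc21` sits at a limit as well, > 50000 nM. Between them, a step that the two limits leave unreadable from compound 1 to compound 3. Compound 2 `O=C(NC(=S)N1CCc2c(OCCCCCOc3ccc(Cl)cc3)cccc21)c1ccc(C(F)(F)F)cc1` gives 32700 nM in this assay, and an at least 1.5-fold higher number from compound 2 to compound 3 (0.18 log units; that floor lies within the scatter), while an at least 1.5-fold lower number from compound 1 to compound 2 (0.18 log units; that floor lies within the scatter). Two of the three values share one limit (the limit of > 50000 nM in this assay, at which 2 of the 3 values shown sit). Compound 4 `O=C(NC(=S)N1CCc2c(OCCCCCOc3ccc(Cl)cc3)cccc21)c1ccoc1` differs from compound 3 by furan-3-yl in place of phenethyl on a carbonyl carbon. The measured steps stay within the scatter or are unreadable, so no shift beyond the scatter is expected, an at least 1.1-fold lower number from compound 3 to compound 4 (0.04 log units; that floor lies within the scatter). Compound 4 is therefore expected to give about 45000 nM, between 20000 nM and 90000 nM, most likely again reported as a limit.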

Compound 4, half-maximal cytotoxic concentration: 20100 nM
Estimate against measurement, compound 4: 2.2-fold (0.35 log units) above; low and high end bracket the measured number.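

In this assay, the group on the carbonyl carbon now moves the read-out beyond the scatter: an at least 2.4-fold lower number from compound 3 to compound 4 (0.39 log units; beyond the scatter), and an at least 2.4-fold lower number from compound 1 to compound 4 (0.39 log units; beyond the scatter). Swapping one aromatic group for the other leaves the number within the scatter: a 1.6-fold lower number from compound 2 to compound 4 (0.21 log units; within the scatter). Both larger steps start from a limit, so their true sizes remain unknown: the limit of > 50000 nM in this assay, at which 2 of the 4 values shown sit.

Still open, on these data alone, is whether this lower number belongs to furan-3-yl itself or to aromatic rings on this carbonyl carbon in general. A plain phenyl or a pyridine at the same place would help to separate those two readings.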